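The source may hold more compounds than are shown below. What is called first, only, known or untested is meant among the compounds shown, and "the series" means these compounds.

Measured so far:
compound 1 `CC(C)n1cnc2c(Nc3ccccc3)nc(NCOCc3ccc(/C=C/C(=O)Nc4ccccc4N)cc3)nc21` — 40.8%
compound 2 `Nc1ccccc1NC(=O)c1ccc(COCNc2nc(Nc3ccccc3)c3ncn(C4CCCC4)c3n2)cc1` — 66.9%
compound 3 `CCCCn1cnc2c(Nc3ccccc3)nc(NCOCc3ccc(/C=C/C(=O)Nc4ccccc4N)cc3)nc21` — 59.3%

In a functional assay on HepG2 cells (Homo sapiens) for antiproliferative activity, read by CCK-8 assay, with a stated time of 72 h, tested at 8 uM (on this read-out higher numbers stand for a stronger effect at the one concentration tested and lower numbers for a weaker effect), compound 3 gives the second highest of the three numbers; compound 2 is nearest, within the scatter, and compound 1 furthest, beyond it. Among the measured compounds shown here, the only single-place step recorded is a number 18.5 percentage points higher from compound 1 to compound 3 (beyond the scatter), a modest gain.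

Compound 4 `Nc1ccccc1NC(=O)/C=C/c1ccc(COCNc2nc(Nc3ccccc3)c3ncn(C4CCCC4)c3n2)cc1` is to be measured. The change from compound 3 is cyclopentyl in place of butyl on an aromatic nitrogen. Compound 2 already carries cyclopentyl on that nitrogen, though with a different linker, and its value sits within the scatter of compound 3. A cyclopentyl-for-butyl step has not been measured directly; the isopropyl-to-butyl step suggests larger groups here do not hurt. For compound 4 the expected step is a number 2.7 percentage points higher from compound 3 to compound 4 (within the scatter), with an estimate of 62% and a range of 48% to 76%.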

Compound 4, a percentage reported as inhibition, at one concentration (the size of the read-out at that concentration, not a potency): 18.8%
Compound 4: middle estimate off by 43.2 percentage points, on the high side; the whole stated range lies above it.
By their numbers in this assay, from the lowest: compound 4; then compound 1; then compounds 3 and 2 (each within the scatter of the next).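

In this assay, cyclopentyl on the aromatic nitrogen gives a number 40.5 percentage points lower from compound 3 to compound 4 (beyond the scatter) against butyl and a number 22 percentage points lower from compound 1 to compound 4 (beyond the scatter) against isopropyl, so the ring falls below both open-chain groups with this linker. Cyclopentyl does not carry a low value with every linker: 2-((2-aminophenyl)carbamoyl)ethenyl in place of (2-aminophenyl)carbamoyl gives a number 48.1 percentage points lower from compound 2 to compound 4 (beyond the scatter), so the effect of the group on the nitrogen depends on the group on the aromatic carbon. No measurement here accounts for this drop.

Going by these compounds, whether a cyclohexyl ring on that nitrogen follows cyclopentyl remains open. So does whether a longer chain such as hexyl follows butyl.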